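From hydroxy to ethyl: a cytotoxicity estimate for compound 3

The source may report more compounds than this note shows. Statements on the series, on what has been measured and on what is new or still open speak of the compounds shown alone.

Among the compounds with values here, in an ADME assay on FSCLL cells (Homo sapiens) for cytotoxicity, read by MTT assay, with a stated time of 24 h (on this read-out higher numbers stand for lower toxicity in this test and lower numbers for higher toxicity in this test), compound 1 `CNCC(=O)N[C@@H](CC(C)C)B(O)O` gives 160 nM, while compound 2 `CC(C)C[C@H](NC(=O)[C@@H](N)CO)B(O)O` gives 1700 nM, the higher of the two numbers so far. Compound 3 `CCC[C@H](N)C(=O)N[C@@H](CC(C)C)B(O)O` differs from compound 2 in one place: ethyl in place of hydroxy on a saturated chain carbon, two bonds along the chain from an amine nitrogen and a carbonyl carbon. This puts ethyl in place of hydroxy on a saturated chain carbon, two bonds along the chain from an amine nitrogen and a carbonyl carbon. Within the data shown here, only one measured step bears on this: an 11-fold higher number from compound 1 to compound 2 (1.03 log units; beyond the scatter), a large move that brought in the hydroxy together with other changes. It is therefore only a partial guide. With the hydroxy gone, part of that move may be undone, so a smaller shift towards lower numbers is expected in this assay. The estimated step is a 4.3-fold lower number from compound 2 to compound 3 (0.63 log units; beyond the scatter). For compound 3 the expected value is 400 nM, with an estimated range of 90 nM to 1700 nM.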

Compound 3, half-maximal cytotoxic concentration: 1100 nM
Compound 3: the middle estimate sits 2.8-fold (0.44 log units) below what was measured; measured number inside the range.
By their numbers in this assay, from the lowest: compound 1; then compounds 3 and 2 (each within the scatter of the next).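

In this assay ethyl in place of hydroxy on a saturated chain carbon gives a 1.5-fold lower number from compound 2 to compound 3 (0.19 log units; within the scatter) and so leaves the two compounds indistinguishable. The hydroxy, with its hydrogen-bond donor and acceptor, is therefore not required at this place for a number in this range. The same holds against the other neighbour: 1-aminobutyl in place of (methylamino)methyl gives a 6.9-fold higher number from compound 1 to compound 3 (0.84 log units; beyond the scatter) and thus keeps most of the earlier rise of an 11-fold higher number from compound 1 to compound 2 (1.03 log units; beyond the scatter) without any hydroxy.

As far as these compounds go, whether a carboxylic acid, an amine or a chain longer than propyl at this place would also leave the number in this range remains open. Nothing available explains why the hydroxy and ethyl compounds read alike in this test.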